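Chloro in place of trifluoromethyl: working notes

A few compounds are considered here, and "the series" means these few. Any claim that something is new, unique, unknown or untested is made for them only; others in the source may bear on it.

Measured so far in an ADME assay on microsomes from liver (Homo sapiens) for metabolic stability, read by LC-MS, with a stated time of 15 min; on this read-out lower numbers stand for a less stable compound and higher numbers for a more stable compound
compound 1 `CCNC(=O)Nc1sc2cc(C)ccc2c1C(=O)N1CCN(C2CCN(C(=O)C(C)(C)CF)CC2)CC1` gives 84%
compound 2 `CCNC(=O)Nc1sc2cc(C(F)(F)F)ccc2c1C(=O)N1CCN(C2CCN(C(=O)C(C)(C)C(F)(F)F)CC2)CC1` gives 7%

Compound 2 (7%) is the lower of the two numbers, set against compound 1 (84%), and the gap between them lies beyond the scatter. These two compounds differ in more than one place, so their gap cannot be assigned to any single change.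

Compound 3 `CCNC(=O)Nc1sc2cc(Cl)ccc2c1C(=O)N1CCN(C2CCN(C(=O)C(C)(C)C(F)(F)F)CC2)CC1` departs from compound 2 in one place: chloro in place of trifluoromethyl on an aromatic carbon. This is chloro in place of trifluoromethyl on an aromatic carbon. Among the measured compounds shown here, no measured pair shows this change alone, so the expectation is anchored on compound 2 (7%), whose remaining structure compound 3 keeps. A small rise in this assay is expected, about the size of the scatter: a number 8 percentage points higher from compound 2 to compound 3 (within the scatter) (estimated). For compound 3 the estimated value is 15% (4% to 40%).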

Compound 3, percent of the compound remaining: 51%
For compound 3 the middle estimate is 36 percentage points below the measured one; measured number outside the range, above it.
By their numbers in this assay, from the lowest: compound 2; then compound 3; then compound 1.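

In this assay, chloro in place of trifluoromethyl on this aromatic carbon gives a number 44 percentage points higher from compound 2 to compound 3 (beyond the scatter). Among the compounds shown here, this is the first reading of this position on its own, since compound 1 and compound 2 differ in more than one place and their gap could not be assigned to any single change. The substituent at this aromatic carbon is therefore enough by itself to move the read-out beyond the scatter, although nothing measured here gives a reason for the step.

From the compounds shown here alone, how a nitrile or a methoxy group at this aromatic carbon would read in this assay remains open, as does whether the step holds when the rest of the structure differs. Compound 1 and compound 3 also differ in more than one place, so no single change accounts for their printed values.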